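Allyl ether to free phenol: a step from a limit

A few compounds are considered here, and "the series" means these few. Any claim that something is new, unique, unknown or untested is made for them only; others in the source may bear on it.

Compound 2 `C=CCOc1c(Cl)cccc1C(=O)c1cccnc1` carries an allyl group on an aromatic oxygen, as does its companion compound 1 `C=CCOc1ccc(F)cc1C(=O)c1cccnc1`. In a functional assay on PC-3 cells (Homo sapiens) for cytotoxicity, read by sulforhodamine B assay, with a stated time of 48 h (on this read-out lower numbers stand for stronger inhibition and higher numbers for weaker inhibition), compound 2 reaches only a limit, > 100000 nM. In this assay compound 1 likewise reaches only a limit, > 100000 nM. Within the data shown here, both known values therefore sit at the same place, (the limit of > 100000 nM in this assay, at which 2 of the 2 values shown sit), and no step between measured compounds can be drawn from them. Compound 3 `O=C(c1cccnc1)c1cccc(Cl)c1O` differs from compound 2 in one place: hydrogen in place of allyl on an oxygen on an aromatic ring, so that allyloxy becomes hydroxy. With both known values at a limit, the measured compounds give no size for this kind of step. The step from compound 2 to compound 3 is expected to stay within the usual scatter, a number no higher from compound 2 to compound 3 (the limit leaves the size open). Compound 3 is thus expected to give about 100000 nM in this assay, within a range from 20000 nM to 300000 nM.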

Compound 3, half-maximal inhibitory concentration: 31500 nM
Estimate against measurement, compound 3: 3.2-fold (0.50 log units) above, within the range that was stated.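

In this assay, hydrogen in place of allyl on the oxygen gives an at least 3.1-fold lower number from compound 2 to compound 3 (0.50 log units; beyond the scatter). Of the compounds shown, only compound 3 has a value that is a true number, 31500 nM, so this oxygen is a place where a change can register on this read-out, which the two allyl ethers alone could not show. The real size of the step stays unknown because its starting point is only a limit: the limit of > 100000 nM in this assay, at which 2 of the 3 values shown sit.

From the compounds shown here alone, this is a single pair, so it remains open whether the same change would have a similar effect on compound 1. Going by these compounds, it is also open how a methoxy group, a longer chain on the oxygen, or an amine in place of the hydroxy would compare with compound 3.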